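Methoxymethyl in Place of Isopropyl: Expected Residence Time

The compounds below may be only part of what the source reports. "The series", "measured", "known", "first", "only" and "open" are said of these compounds alone.

Of the compounds shown here, three sharing one core have been measured in an ADME assay on the whole organism (Macaca fascicularis); on this read-out lower numbers stand for a shorter-lived compound and higher numbers for a longer-lived compound. Compound 1 `Cc1ccc(-c2nc(=O)o[nH]2)c(-c2ccc([C@@H](C)N(CC3CC3)c3nc(C(=O)NS(=O)(=O)C4CC4)c(C(C)C)s3)cc2)c1` gives 5.2 h. Compound 2 `Cc1ccc(-c2nc(=O)o[nH]2)c(-c2ccc([C@@H](C)N(CC3CC3)c3nc(C(=O)NS(=O)(=O)C4CC4)c(CC(C)C)s3)cc2)c1` gives 4.9 h. Compound 3 `Cc1ccc(-c2nc(=O)o[nH]2)c(-c2ccc([C@@H](C)N(CC3CC3)c3nc(C(=O)NS(=O)(=O)C4CC4)c(C4CCC4)s3)cc2)c1` gives 5.7 h. All three differ only in the group on one aromatic carbon, and every step among them stays within the scatter: a 1.1-fold lower number from compound 1 to compound 2 (0.03 log units; within the scatter), a 1.1-fold higher number from compound 1 to compound 3 (0.04 log units; within the scatter) and a 1.2-fold higher number from compound 2 to compound 3 (0.07 log units; within the scatter). Compound 2 therefore stands among numbers that this assay cannot tell apart.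

Compound 4 `COCCc1sc(N(CC2CC2)[C@H](C)c2ccc(-c3cc(C)ccc3-c3nc(=O)o[nH]3)cc2)nc1C(=O)NS(=O)(=O)C1CC1` differs from compound 2 by methoxymethyl in place of isopropyl on a saturated chain carbon bound to an aromatic carbon. The measured steps bear on it only loosely: they show that exchanging one small carbon group for another at this part of the core left this assay unchanged, but none of them brings in a group of a different kind, so the comparison is weaker than it looks. With no step beyond the scatter anywhere in the series, the expectation is that this assay shows no step beyond the scatter, with a 1.1-fold lower number from compound 2 to compound 4 (0.04 log units; within the scatter). Compound 4 is estimated at 4.5 h, within a range from 2.5 h to 8 h.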

Compound 4, mean residence time: 4.2 h
Beside the measured number, compound 4's estimate is 1.1-fold (0.03 log units) above it; low and high end bracket the measured number.
By their numbers in this assay, from the lowest: compounds 4, 2, 1 and 3 (each within the scatter of the next).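

Methoxymethyl in place of isopropyl brings the first oxygen into this group, and with it the first hydrogen-bond acceptor, while the count stays at 3 heavy atoms. Even so, this assay does not separate the resulting 2-methoxyethyl group from the all-carbon groups, with a 1.2-fold lower number from compound 2 to compound 4 (0.07 log units; within the scatter), a 1.2-fold lower number from compound 1 to compound 4 (0.09 log units; within the scatter) and a 1.4-fold lower number from compound 3 to compound 4 (0.13 log units; within the scatter); even the largest of these steps, the one from the cyclobutyl compound, stays inside the scatter. Nothing measured here offers a reason for this flat result.

From the compounds shown here alone, whether a charged group at this position, such as an amine or a carboxylic acid, would move the number beyond the scatter remains open. The same question stands for a longer chain ending in a methoxy group or a hydroxyl group.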